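The compounds below may be only part of what the source reports. "The series", "measured", "known", "first", "only" and "open" are said of these compounds alone.

Measured compounds in an assay on HEK293 cells for activation of potassium channel subfamily T member 1 (Homo sapiens), read by thallium flux; a higher number here means that more compound is needed for the effect, a lower number that less compound is needed:
Compound 1, `COc1ccc(NC(=O)CN2CCN(S(=O)(=O)N3CCC(C)CC3)CC2)cc1`, reached only the assay limit > 10000 nM.
Compound 2, `CC1CCN(S(=O)(=O)N2CCN(CC(=O)Nc3cccc(Cl)c3)CC2)CC1`, gave 7600 nM.
Compound 3, `CC1CCN(S(=O)(=O)N2CCN(CC(=O)Nc3cc(Cl)ccc3F)CC2)CC1`, gave 3800 nM.

In this assay compound 3 and compound 2 are separated by a 2.0-fold lower number from compound 2 to compound 3 (0.30 log units; within the scatter), a gap within the scatter, so the two are not distinguished by these numbers. The value of compound 1 is a limit only (the limit of > 10000 nM in this assay, at which 1 of the 3 values shown sits). Compound 4, `CC1CCN(S(=O)(=O)N2CCN(CC(=O)Nc3ccccc3)CC2)CC1`, differs from compound 3 by phenyl in place of 5-chloro-2-fluorophenyl on an amide-type nitrogen. Of the measured steps, a 2.0-fold lower number from compound 2 to compound 3 (0.30 log units; within the scatter) is the closest guide: dropping fluoro alone shifted the number within the scatter. The steps of an at least 1.3-fold lower number from compound 1 to compound 2 (0.11 log units; that floor lies within the scatter) and an at least 2.6-fold lower number from compound 1 to compound 3 (0.42 log units; beyond the scatter) show that both chloro-bearing aryl groups fall under the limit of compound 1, whereas compound 4 keeps neither chloro nor fluoro. A higher number is therefore expected for compound 4 in this assay, a 3.2-fold higher number from compound 3 to compound 4 (0.50 log units; beyond the scatter), probably beyond the scatter and possibly reaching the assay limit. Compound 4 is estimated at 12000 nM, with a range from 5000 nM to 30000 nM.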

Compound 4, half-maximal effective concentration: > 10000 nM
Compound 4: only a limit was reported; the forecaster's own chance of this, stated with the estimate: 55%; the middle value is on the limit's open side.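

In this assay compound 4, which carries plain phenyl on the amide-type nitrogen, gave only a limit of the assay, > 10000 nM. With both halogens gone, the change shows an at least 2.6-fold higher number from compound 3 to compound 4 (0.42 log units; beyond the scatter), which gives the first reading against an unsubstituted phenyl and shows that the 5-chloro-2-fluorophenyl group holds an advantage over it here. The comparison for chloro alone gives an at least 1.3-fold higher number from compound 2 to compound 4 (0.11 log units; that floor lies within the scatter), so the contribution of chloro by itself is not resolved.

The step between compound 1 and compound 4 cannot be read, which leaves methoxy and hydrogen on the ring unranked: the limit of > 10000 nM in this assay, at which 2 of the 4 values shown sit. On these data alone, whether an amine, a carboxylic acid or a longer alkyl chain on this aryl ring would bring the number lower remains open.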